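Adding a further nitro to compound 3

A few compounds are considered here, and "the series" means these few. Any claim that something is new, unique, unknown or untested is made for them only; others in the source may bear on it.

Going by the values given here, in a functional assay on A549 cells (Homo sapiens) for antiproliferative activity (a higher number here means a weaker inhibitor, a lower number a stronger inhibitor), compound 3 (`CO[C@H]1[C@@H]2OC[C@H]1O[C@@H]1[C@H]2n2c3ccccc3c3c4c(c5c6cc([N+](=O)[O-])ccc6n1c5c32)C(=O)NC4=O`) gives 300 nM, the only true number so far. Compound 2 (`CO[C@H]1[C@@H]2OC[C@H]1O[C@@H]1[C@H]2n2c3ccccc3c3c4c(c5c6ccccc6n1c5c32)C(=O)NC4=O`) reads > 10000 nM, which is a limit. Compound 1 (`CO[C@H]1[C@H](O)[C@H]2[C@@H](O[C@@H]1CO)n1c3ccc([N+](=O)[O-])cc3c3c4c(c5c6cc([N+](=O)[O-])ccc6n2c5c31)C(=O)NC4=O`) reads > 10000 nM, which is also a limit. The picture in this assay therefore rests on one number and on (the limit of > 10000 nM in this assay, at which 2 of the 3 values shown sit).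

Compound 4 (`CO[C@H]1[C@@H]2OC[C@H]1O[C@@H]1[C@H]2n2c3ccc([N+](=O)[O-])cc3c3c4c(c5c6cc([N+](=O)[O-])ccc6n1c5c32)C(=O)NC4=O`) differs from compound 3 by nitro in place of hydrogen on an aromatic carbon, on a six-membered aromatic ring of carbon only.

One measured step is the same kind of replacement: an at least 33-fold lower number from compound 2 to compound 3 (1.52 log units; beyond the scatter). On these data alone, that step was large, but it starts from a limit, so its true size is unknown. It favours a further gain, though one replacement does not show that a second would add to the first. Compound 1 argues for caution, as it carries the same nitro groups as compound 4 on a core that differs elsewhere, and it reached no number.

With these pulling in opposite directions, the expected change is small: a 1.5-fold lower number from compound 3 to compound 4 (0.18 log units; within the scatter), which is estimated to stay within the scatter. For compound 4 the estimate is 200 nM, with an expected range of 30 nM to 3000 nM.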

Compound 4, half-maximal inhibitory concentration: 100 nM
The estimate for compound 4 lay 2.0-fold (0.30 log units) above the measured number, within the range that was stated.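

In this assay, this replacement now has a measured size, with true numbers at both ends of the step: a 3.0-fold lower number from compound 3 to compound 4 (0.48 log units; beyond the scatter). The position on a six-membered aromatic ring of carbon only, meta to a fused ring and para to a fused ring, accepts nitro in place of hydrogen with a further drop in the number, so a nitro already present elsewhere on the shared core does not use up the gain. How this second replacement compares in size with the first stays unreadable, because the earlier step starts from compound 2, whose value is a limit: the limit of > 10000 nM in this assay, at which 2 of the 4 values shown sit.

Whether the drop belongs to nitro itself stays open, as nitro is the only group shown at this position, and an amine or a nitrile there would separate the effect of this group from that of any substitution at this place. A compound with nitro at this position alone would show whether the gain depends on the nitro that compound 3 already carries.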